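The source may report more compounds than this note shows. Statements on the series, on what has been measured and on what is new or still open speak of the compounds shown alone.

In a functional assay on IGROV-1 cells (Homo sapiens) for inhibition (a higher number here means a weaker inhibitor of growth, a lower number a stronger inhibitor of growth), compound 1 `Cc1cc(-c2nc3c(F)cccc3s2)ccc1N` gives 22900 nM and compound 2 `Nc1ccc(-c2nc3cc(F)ccc3s2)cc1` gives 11500 nM, so these two values lie within the usual scatter of each other. Compound 3 `Cc1cc(-c2nc3cc(F)c(F)cc3s2)ccc1N` gives < 10 nM, which is a limit of the assay and not an exact number. Compound 4 `Nc1ccc(-c2nc3cc(F)ccc3s2)cc1I` departs from compound 2 in one place: iodo in place of hydrogen on an aromatic carbon, with iodo in place of hydrogen on an aromatic carbon, ortho to an amino group. Within the data shown here, no measured pair isolates this change, so any forecast is uncertain. A large step towards stronger growth inhibition is expected, on the thin evidence that compound 3 reaches the limit of < 10 nM. The expected change is a 38-fold lower number from compound 2 to compound 4 (1.58 log units; beyond the scatter). For compound 4 the estimated value is 300 nM, with an expected range from 10 nM to 12000 nM.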

Compound 4, concentration for 50% growth inhibition: < 10 nM
Compound 4 gave a limit, no number; the forecaster's own chance of this, stated with the estimate: 20%; at least 30-fold (1.47 log units) between middle value and limit.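

Among these compounds, until now no pair of compounds isolated a change at this place; here iodo in place of hydrogen on an aromatic carbon, ortho to an amino group, gives an at least 1100-fold lower number from compound 2 to compound 4 (3.06 log units; beyond the scatter) as the whole effect of a single atom. That one change is enough to carry compound 2 to the edge of what the read-out can report. The value of compound 4 is a limit and not a number, so the full size of the step cannot be read: the limit of < 10 nM in this assay, at which 2 of the 4 values shown sit.

Going by these compounds, whether chloro, bromo or a methoxy group at the same place would give a step of similar size stays open. On these data alone, how much stronger compound 4 really is than its limit also stays open.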